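A pyridin-2-yl group replaces ethyl on the ring nitrogen

The compounds below may be only part of what the source reports. "The series", "measured", "known", "first", "only" and "open" are said of these compounds alone.

In an ADME assay on microsomes from liver (Mus musculus) for metabolic stability, read by LC-MS, with a stated time of 10 min (on this read-out lower numbers stand for a less stable compound and higher numbers for a more stable compound), three compounds with a shared core have been measured, and they differ only in the group on an amine nitrogen in a ring. Compound 1 `CN(C[C@H]1Cc2c(cccc2N2CCN(C3CC3)CC2)CN1)[C@H]1CCCc2cccnc21`, with cyclopropyl, gives 7%, and compound 2 `CN(C[C@H]1Cc2c(cccc2N2CCN(c3cccc(C(F)(F)F)c3)CC2)CN1)[C@H]1CCCc2cccnc21`, with 3-(trifluoromethyl)phenyl, gives 72.3%. Compound 3 `CCN1CCN(c2cccc3c2C[C@H](CN(C)[C@H]2CCCc4cccnc42)NC3)CC1`, with ethyl, gives 18.8%, second highest of the three and much nearer to compound 1 than to compound 2.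

Compound 4 `CN(C[C@H]1Cc2c(cccc2N2CCN(c3ccccn3)CC2)CN1)[C@H]1CCCc2cccnc21` carries pyridin-2-yl in place of ethyl on that nitrogen: pyridin-2-yl in place of ethyl on an amine nitrogen in a ring. Going by the values given here, three measured steps bear on this change. Ethyl in place of 3-(trifluoromethyl)phenyl gave a number 53.5 percentage points lower from compound 2 to compound 3 (beyond the scatter), and 3-(trifluoromethyl)phenyl in place of cyclopropyl gave a number 65.3 percentage points higher from compound 1 to compound 2 (beyond the scatter), while ethyl in place of cyclopropyl gave only a number 11.8 percentage points higher from compound 1 to compound 3 (beyond the scatter). Among the compounds with values here, compound 2, at 72.3%, is the only measured compound with an aromatic ring at this place, so the guidance rests on a single case. Pyridin-2-yl also has no trifluoromethyl group, so a rise of moderate to large size is expected, short of the full gap to compound 2. The expected change is a number 29.2 percentage points higher from compound 3 to compound 4 (beyond the scatter). For compound 4 the estimate is 48%, with an expected range from 25% to 72%.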

Compound 4, percent of the compound remaining: 46.1%
Beside the measured number, compound 4's estimate is 1.9 percentage points above it; low and high end bracket the measured number.
By their numbers in this assay, from the lowest: compound 1; then compound 3; then compound 4; then compound 2.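

In this assay, the high number for an aromatic ring on this amine nitrogen no longer rests on compound 2 alone: pyridin-2-yl in place of ethyl gives a number 27.3 percentage points higher from compound 3 to compound 4 (beyond the scatter), and pyridin-2-yl in place of cyclopropyl gives a number 39.1 percentage points higher from compound 1 to compound 4 (beyond the scatter). Among these four compounds, then, the two with an aromatic ring on this nitrogen both stand above the two without one, and no compound goes against that order. The ring alone does not reach the top number, since pyridin-2-yl in place of 3-(trifluoromethyl)phenyl gives a number 26.2 percentage points lower from compound 2 to compound 4 (beyond the scatter), a change that swaps a ring carbon for a ring nitrogen and removes the trifluoromethyl group in a single step.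

No measurement presented here accounts for any of these differences. The compounds shown cannot separate the part played by the ring nitrogen from that of the trifluoromethyl group, and an unsubstituted phenyl at this place would bear directly on that question, while a longer chain such as butyl would test whether a non-aromatic group can also give a high number.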